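A Different Group on the Sulfonyl Sulfur

The compounds below may be only part of what the source reports. "The series", "measured", "known", "first", "only" and "open" are said of these compounds alone.

Of the compounds shown here, two sharing one core have been measured in a functional assay on K562 cells (Homo sapiens) for inhibition, read by trypan blue exclusion, with a stated time of 72 h; on this read-out lower numbers stand for stronger inhibition and higher numbers for weaker inhibition. Compound 1 (`Cn1c(=O)c(S(=O)(=O)Cc2ccc(F)cc2)cc2cnc(Nc3ccc4[nH]ccc4c3)nc21`) gives 30000 nM, the higher of the two numbers. Compound 2 (`Cn1c(=O)c(C(=O)Nc2ccc(F)cc2)cc2cnc(Nc3ccc4[nH]ccc4c3)nc21`) gives 5000 nM. For the measured compounds named here, the one measured step is a 6.0-fold lower number from compound 1 to compound 2 (0.78 log units; beyond the scatter), with (4-fluorophenyl)carbamoyl in place of (4-fluorobenzyl)sulfonyl on an aromatic carbon.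

Compound 3 (`Cn1c(=O)c(S(=O)(=O)c2ccc(F)cc2[N+](=O)[O-])cc2cnc(Nc3ccc4[nH]ccc4c3)nc21`) keeps the sulfonyl and differs from compound 1 in the group it carries: 4-fluoro-2-nitrophenyl in place of 4-fluorobenzyl on a sulfonyl sulfur. Here 4-fluoro-2-nitrophenyl stands in place of 4-fluorobenzyl on a sulfonyl sulfur. Going by the values given here, no measured pair isolates this change, so the step to compound 2 bears on it only indirectly, as that step replaces the whole sulfonyl group. It does show that a change at this part of compound 1 can shift the number by a modest amount. A step toward a lower number in this assay is therefore expected, smaller than the measured one, and a result within the scatter would be unsurprising. The expected step is a 2.0-fold lower number from compound 1 to compound 3 (0.30 log units; within the scatter). The estimate for compound 3 is 15000 nM, with an expected range of 4000 nM to 50000 nM.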

Compound 3, half-maximal inhibitory concentration: 900 nM
Compound 3: the middle estimate sits 17-fold (1.22 log units) above what was measured; the whole stated range lies above it.
By their numbers in this assay, from the lowest: compound 3; then compound 2; then compound 1.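

In this assay, the number can fall without giving up the sulfonyl group: with the sulfonyl kept, 4-fluoro-2-nitrophenyl in place of 4-fluorobenzyl on a sulfonyl sulfur gives a 33-fold lower number from compound 1 to compound 3 (1.52 log units; beyond the scatter). This step is larger than a 6.0-fold lower number from compound 1 to compound 2 (0.78 log units; beyond the scatter), the step that replaced the whole sulfonyl group, so in this series the group carried on the sulfur can move the number further than that exchange did. Nothing available explains the size of the step or says how the change acts.

The step combines two differences, the benzyl group giving way to a phenyl ring on the sulfur and the arrival of a nitro group, and the compounds shown leave open which of them accounts for the drop, a question that a plain 4-fluorophenyl on the sulfonyl sulfur would help to separate. Also open, on these data alone, is whether an amine, a nitrile or a carboxylic acid in place of the nitro group would keep a number close to that of compound 3, at 900 nM.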